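Swapping propanoyl for phenyl on the aniline nitrogen

The compounds below may be only part of what the source reports. "The series", "measured", "known", "first", "only" and "open" are said of these compounds alone.

Measured in an ADME assay on A549 cells (Homo sapiens) for cytotoxicity, read by MTT assay, with a stated time of 4 days (on this read-out higher numbers stand for weaker inhibition and lower numbers for stronger inhibition), all three values being limits:
- compound 1 `COc1cc(C[C@H]2C(=O)OC[C@@H]2Cc2ccc(OC)c(OC)c2)ccc1N`: > 50000 nM
- compound 2 `COc1cc(C[C@H]2C(=O)OC[C@@H]2Cc2ccc(OC)c(OC)c2)ccc1NC(C)=O`: > 50000 nM
- compound 3 `CCC(=O)Nc1ccc(C[C@H]2C(=O)OC[C@@H]2Cc2ccc(OC)c(OC)c2)cc1OC`: > 50000 nM

Compound 3 has no exact number, only a limit shared with the other two compounds: the limit of > 50000 nM in this assay, at which 3 of the 3 values shown sit. Compound 4 `COc1cc(C[C@H]2C(=O)OC[C@@H]2Cc2ccc(OC)c(OC)c2)ccc1Nc1ccccc1` carries phenyl in place of propanoyl on a nitrogen on an aromatic ring. The closest measured changes at this nitrogen are a step that the two limits leave unreadable from compound 1 to compound 2 and a step that the two limits leave unreadable from compound 1 to compound 3, while the chain change is a step that the two limits leave unreadable from compound 2 to compound 3. None gives a size, and none tests phenyl, so no step beyond the scatter can be predicted in this assay. The estimated change is a number no higher from compound 3 to compound 4 (the limit leaves the size open). Compound 4 is expected at 50000 nM, with an estimated range of 20000 nM to 100000 nM.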

Compound 4, half-maximal inhibitory concentration: > 50000 nM
Compound 4: only a limit was reported (the forecaster's own chance of this, stated with the estimate: 75%); the middle value lies on the limit itself.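

No step can be read among compound 1, compound 2, compound 3 and compound 4, as each value is only a limit: the limit of > 50000 nM in this assay, at which 4 of the 4 values shown sit. As far as these compounds go, whether hydrogen, acetyl, propanoyl or phenyl on the nitrogen changes the exact value in this assay stays open.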